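The source may hold more compounds than are shown below. What is called first, only, known or untested is meant among the compounds shown, and "the series" means these compounds.

Measured so far in a physicochemical assay for solubility, read by spectrophotometry, in phosphate buffer, with a stated time of 18 h, at pH 7.4; on this read-out higher numbers stand for higher solubility and lower numbers for lower solubility:
Compound 1 `CCc1ccc(-c2nc3c(c(C)nn3-c3ccccc3)c(-c3ccccc3C(=O)OC)c2C#N)cc1`: 17000 nM
Compound 2 `C#Cc1ccccc1-c1c(C#N)c(-c2ccc(CC)cc2)nc2c1c(C)nn2-c1ccccc1`: 46000 nM
Compound 3 `Cc1nn(-c2ccccc2)c2nc(-c3ccc(C(C)C)cc3)c(C#N)c(-c3ccccc3O)c12`: 9800 nM

In this assay, compound 3 at 9800 nM lies within the usual scatter of compound 1 at 17000 nM. Both stand clearly under compound 2 at 46000 nM.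

The next compound is compound 4 `Cc1nn(-c2ccccc2)c2nc(-c3ccc(C#N)cc3)c(C#N)c(-c3ccccc3O)c12`, which has not yet been measured. It departs from compound 3 at one place, with cyano in place of isopropyl on an aromatic carbon, so that 4-isopropylphenyl becomes 4-cyanophenyl: cyano in place of isopropyl on an aromatic carbon.

Within the data shown here, only one measured step changes a single place: a 2.7-fold higher number from compound 1 to compound 2 (0.43 log units; beyond the scatter). This modest step, beyond the scatter, swaps methoxycarbonyl for ethynyl, which is a different exchange at a different place. It therefore bears on the new change only loosely, showing the size a single exchange has reached among these compounds, but not its direction here. Among the measured compounds shown here, no measured step exchanges isopropyl or cyano, so the direction remains uncertain. For the measured compounds named here, a small rise is expected, no larger than the step from compound 1, and probably not beyond the scatter. The expected step is a 1.4-fold higher number from compound 3 to compound 4 (0.15 log units; within the scatter). For compound 4, the estimated value is 14000 nM, with an expected range from 5000 nM to 40000 nM.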

Compound 4, solubility: 1700 nM
The estimate for compound 4 lay 8.2-fold (0.92 log units) above the measured number; the measured number lies below the stated range.
By their numbers in this assay, from the lowest: compound 4; then compounds 3 and 1 (each within the scatter of the next); then compound 2.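

In this assay, placing cyano in place of isopropyl on an aromatic carbon, para to a large group, gave a 5.8-fold lower number from compound 3 to compound 4 (0.76 log units; beyond the scatter), so changing 4-isopropylphenyl to 4-cyanophenyl moves the number beyond the scatter, and downward. Among these compounds, the earlier compounds had offered only one single-place step, a 2.7-fold higher number from compound 1 to compound 2 (0.43 log units; beyond the scatter), which was an upward move from a different exchange at a different place, so this is the first evidence on this position and shows that a single change here can matter. Cyano brings a hydrogen-bond acceptor and a triple bond that isopropyl lacks, but no measurement presented here explains why the number fell.

Going by these compounds, it remains open whether the fall is particular to cyano or would also appear with an amine, a carboxylic acid or a longer chain at this place. On these data alone, it is also open whether the same exchange would lower the number to a similar extent on compounds carrying methoxycarbonyl or ethynyl, as compound 1 and compound 2 do, at the other varied place.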